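Carbamoyl to methoxy: working notes on compound 4

The source may report more compounds than this note shows. Statements on the series, on what has been measured and on what is new or still open speak of the compounds shown alone.

Measured so far in a functional assay (aorta) with Oryctolagus cuniculus as the target; a lower number here means tighter binding, a higher number weaker binding
- compound 1 `COc1cc(C(C)=O)ccc1OCCCN1CCC(C(c2ccc(C)cc2)c2ccc(C)cc2)CC1` gives 15.9 nM
- compound 2 `COc1cc(C#N)ccc1OCCCN1CCC(C(c2ccc(F)cc2)c2ccc(F)cc2)CC1` gives 2 nM
- compound 3 `NC(=O)c1ccc(OCCCN2CCC(C(c3ccc(F)cc3)c3ccc(F)cc3)CC2)cc1` gives 31.6 nM

Compound 3 (31.6 nM) lies within the scatter of compound 1 (15.9 nM) and well above compound 2 (2 nM). The next structure is compound 4 `COc1ccc(OCCCN2CCC(C(c3ccc(F)cc3)c3ccc(F)cc3)CC2)cc1` with this difference: methoxy in place of carbamoyl on an aromatic carbon that is, methoxy in place of carbamoyl on an aromatic carbon, para to a large group.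

Within the data shown here, one measured step bears on this, and it is large: a 16-fold higher number from compound 2 to compound 3 (1.20 log units; beyond the scatter) with 4-carbamoylphenyl in place of 4-cyano-2-methoxyphenyl. That step swaps more than one group, so it does not isolate the carbamoyl. Compound 2 carries methoxy, lacks carbamoyl and gives a low number (2 nM). Against that, compound 1 also lacks carbamoyl, differs elsewhere as well, and gives 15.9 nM in the same range as compound 3.

The step expected in this assay is a 2.6-fold lower number from compound 3 to compound 4 (0.42 log units; beyond the scatter) with the direction toward a lower number held only loosely. The estimated value for compound 4 is 12 nM with an expected range from 3 nM to 45 nM (in this assay).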

Compound 4, dissociation constant: 2.51 nM
The estimate for compound 4 lay 4.8-fold (0.68 log units) above the measured number, outside the stated range (below it).
By their numbers in this assay, from the lowest: compounds 2 and 4 (each within the scatter of the next); then compounds 1 and 3 (each within the scatter of the next).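

In this assay, the change at this position, on an aromatic carbon para to a large group, now stands alone, without the other swaps of the earlier comparison, and carbamoyl to methoxy gives a 13-fold lower number from compound 3 to compound 4 (1.10 log units; beyond the scatter) on the shared core. The change to 4-methoxyphenyl from 4-cyano-2-methoxyphenyl gives a 1.3-fold higher number from compound 2 to compound 4 (0.10 log units; within the scatter) with no shift beyond the scatter, so among these compounds the high number of compound 3 goes with the carbamoyl, while nitrile and the second methoxy show no separate mark. Nothing at hand gives a reason for the size of this step.

As far as these compounds go, whether methoxy itself matters, or only the loss of carbamoyl, stays open; a hydroxyl, an amine or a carboxylic acid at this position would help separate the two. Compound 1 differs from the others in more than one place, so its acetyl and methyl groups cannot be read on their own.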